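Nitrophenyl to Difluorophenyl: What Growth Inhibition to Expect

The source may report more compounds than this note shows. Statements on the series, on what has been measured and on what is new or still open speak of the compounds shown alone.

Of the compounds shown here, three built on one shared core have been tested in a functional assay on MCF7 cells (Homo sapiens) for inhibition, read by MTT assay, with a stated time of 48 h, tested at 10 uM; on this read-out higher numbers stand for more inhibition of growth at the one concentration tested and lower numbers for less inhibition of growth. Compound 1, `Cc1cc(=O)c2c(O)cc(O)c([C@H]3CCN(C)C[C@H]3OC(=O)c3ccco3)c2o1`, gives 20%. Compound 2, `Cc1cc(=O)c2c(O)c(CN3CCN(C(=O)OC(C)(C)C)CC3)c(O)c([C@H]3CCN(C)C[C@H]3O)c2o1`, gives 16%. For the measured compounds named here, compound 3, `Cc1oc2c([C@H]3CCN(C)C[C@H]3O)c(O)cc(O)c2c(=O)c1C(O)c1ccc([N+](=O)[O-])cc1`, gives 4%, the lowest of the three numbers; its gap to compound 2 and its gap to compound 1 both lie beyond the usual scatter of repeated runs, so compound 3 is the least active of the compounds measured so far.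

Compound 4, `Cc1oc2c([C@H]3CCN(C)C[C@H]3O)c(O)cc(O)c2c(=O)c1C(O)c1cc(F)cc(F)c1`, has not yet been measured. It differs from compound 3 in a single place: 3,5-difluorophenyl in place of 4-nitrophenyl on a saturated chain carbon bound to an aromatic carbon and an oxygen on a saturated carbon. Going by the values given here, no measured pair of compounds shows this same change, so its effect cannot be read off from the numbers at hand. Among the compounds with values here, nothing among the measured compounds points to a large shift in either direction, and the step expected from this change is a number 6 percentage points higher from compound 3 to compound 4 (within the scatter), which is no larger than the scatter of repeated measurements. On that basis compound 4 is estimated to give 10%, with a range from 0% to 28%.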

Compound 4, percent growth inhibition at one concentration: 25%
Estimate against measurement, compound 4: 15 percentage points below; low and high end bracket the measured number.
By their numbers in this assay, from the lowest: compound 3; then compounds 2, 1 and 4 (each within the scatter of the next).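

In this assay, the change of 3,5-difluorophenyl in place of 4-nitrophenyl gives a number 21 percentage points higher from compound 3 to compound 4 (beyond the scatter). For the compounds shown here, this is the first pair that differs in one place, and it shows that the ring on this saturated chain carbon, bound to an aromatic carbon and an oxygen on a saturated carbon, can move the number by more than repeat runs would. Nothing at hand measures why the swap has this effect.

Going by these compounds alone, with only this one pair, the removal of the nitro group cannot be told apart from the addition of the two fluorines. A plain phenyl ring would help separate the two, while an amine or a carboxylic acid on the ring would test how far this place tolerates other groups.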